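A Ring Replaces a Short Chain on the Amide Nitrogen

A few compounds are considered here, and "the series" means these few. Any claim that something is new, unique, unknown or untested is made for them only; others in the source may bear on it.

Compound 3 `CC(C)(C)C#Cc1cc(N(CCO)C(=O)[C@H]2CC[C@H](C)CC2)c(C(=O)O)s1` carries a 2-hydroxyethyl group on its amide-type nitrogen. In an ADME assay on MT4 cells (Homo sapiens) for cytotoxicity, with a stated time of 5 days (on this read-out lower numbers stand for higher toxicity in this test and higher numbers for lower toxicity in this test), compound 3 reaches only the limit of the test, giving > 20000 nM. Its two relatives share the same core. Compound 1 `CC(C)N(c1cc(C#CC(C)(C)C)sc1C(=O)O)C(=O)[C@H]1CC[C@H](C)CC1` bears an isopropyl group on that nitrogen, and in this assay compound 1 also gives only a limit, > 20000 nM. Compound 2 `C[C@@H](CCOc1cccnc1)N(c1cc(C#CC(C)(C)C)sc1C(=O)O)C(=O)[C@H]1CC[C@H](C)CC1` bears a 1-methyl-3-((pyridin-3-yl)oxy)propyl group there, and in this assay compound 2 likewise gives a limit, > 20000 nM. Because of the limit of > 20000 nM in this assay, at which 3 of the 3 values shown sit, none of the steps between them can be read: a step that the two limits leave unreadable from compound 1 to compound 3, a step that the two limits leave unreadable from compound 1 to compound 2 and a step that the two limits leave unreadable from compound 2 to compound 3.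

Compound 4 `CC(C)(C)C#Cc1cc(N(C(=O)[C@H]2CC[C@H](C)CC2)[C@H]2CC[C@H](O)CC2)c(C(=O)O)s1` is the next variation: 4-hydroxycyclohexyl in place of 2-hydroxyethyl on an amide-type nitrogen. Three quite different groups on this nitrogen have each left the read-out at the limit, so the change to a hydroxylated ring is expected to leave it there as well, and the step from compound 3 to compound 4 is expected to be a step that the limit leaves unreadable from compound 3 to compound 4, nothing beyond the scatter. The value for compound 4 is therefore estimated at 30000 nM, within 15000 nM to 100000 nM, with a limit rather than a number again the most likely report.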

Compound 4, half-maximal cytotoxic concentration: > 20000 nM
Compound 4: only a limit was reported; the forecaster's own chance of this, stated with the estimate: 85%; the middle value does not contradict the limit.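

Compound 4 also gives only a limit, so the steps linking it to compound 1, compound 2 and compound 3 cannot be read, because every value shown stops at the same point: the limit of > 20000 nM in this assay, at which 4 of the 4 values shown sit. The compounds shown leave open whether any group on the amide-type nitrogen changes the read-out in this assay, as none of them gives a number.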